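This account rests on a few compounds, and the source may have more. Where it says the series, first, only, none or still open, it means among the compounds named here.

Compound 1 `CCc1ccc(C(=O)OCc2cn(-c3ccnc4cc(Cl)ccc34)nn2)cc1` gives, in an ADME assay on HepG2 cells (Homo sapiens) for cytotoxicity, read by MTT assay, with a stated time of 24 h (on this read-out higher numbers stand for lower toxicity in this test and lower numbers for higher toxicity in this test), the value > 2550000 nM, which is a limit of the assay.
Compound 2 `CCc1ccccc1C(=O)OCc1cn(-c2ccnc3cc(Cl)ccc23)nn1` gives in this assay the value > 2550000 nM, also a limit of the assay.
Compound 3 `CC(C)(C)c1ccc(C(=O)OCc2cn(-c3ccnc4cc(Cl)ccc34)nn2)cc1` gives in this assay the value > 2380000 nM, again a limit of the assay.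

All three measured compounds share one core and differ only in the aromatic ester group. Compound 3 stands at the limit of > 2380000 nM in this assay, at which 1 of the 3 values shown sits, while compounds 1 and 2 stand at the limit of > 2550000 nM in this assay, at which 2 of the 3 values shown sit; none of the three shows a number within the tested range. The steps between them, a step that the two limits leave unreadable from compound 1 to compound 2, a step that the two limits leave unreadable from compound 1 to compound 3 and a step that the two limits leave unreadable from compound 2 to compound 3, therefore cannot be read in size or direction.

Compound 4 `O=C(OCc1cn(-c2ccnc3cc(Cl)ccc23)nn1)c1ccccc1` is not yet measured. It differs from compound 3 by hydrogen in place of tert-butyl on an aromatic carbon. Among the measured compounds shown here, no measured step bears directly on this change, since every measured step rests on two limits. Because compound 3 stands at the limit of > 2380000 nM in this assay, at which 1 of the 3 values shown sits, and compounds 1 and 2 stand at the limit of > 2550000 nM in this assay, at which 2 of the 3 values shown sit, compound 4 is expected to remain at or near the limit in this assay as well, with no readable step expected in a step that the limit leaves unreadable from compound 3 to compound 4. The estimate for compound 4 in this assay is 2500000 nM, between 1000000 nM and 5000000 nM.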

Compound 4, half-maximal cytotoxic concentration: > 2740000 nM
Compound 4: no number, only a limit (the forecaster's own chance of this, stated with the estimate: 80%); middle value at least 1.0-fold (0.03 log units) from the limit.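

In this assay compound 4 gives > 2740000 nM, which is again a limit of the assay. Compounds 1, 2 and 3 also stand at limits, so none of the steps to compound 4 can be read in size or direction. The compounds shown leave open at what concentration any of them would reach the half-maximal cytotoxic effect, and whether the aromatic ester group changes it.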